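Adding a Third Acetoxy Group to Compound 3

The source may report more compounds than this note shows. Statements on the series, on what has been measured and on what is new or still open speak of the compounds shown alone.

Of the compounds shown here, three sharing one core have been tested in an assay on CHO cells for displacement of a labelled ligand from adenosine receptor A2b (Homo sapiens), read by radioligand binding; on this read-out higher numbers stand for weaker inhibition and lower numbers for stronger inhibition. Compound 1 `CCOc1cccc2cc(-c3ccc([N+](=O)[O-])cc3)c(=O)oc12` gives > 30000 nM, which is a limit of the assay rather than a number. Compound 2 `CC(=O)Oc1cccc2cc(-c3ccccc3)c(=O)oc12` likewise gives > 30000 nM, a limit. Compound 3 `CC(=O)Oc1ccc2cc(-c3ccccc3)c(=O)oc2c1OC(C)=O` gives > 30000 nM, again only a limit. The step that the two limits leave unreadable from compound 2 to compound 3 therefore cannot be read, because both of its ends sit at the limit of > 30000 nM in this assay, at which 3 of the 3 values shown sit. Compound 4 `CC(=O)Oc1ccc(-c2cc3ccc(OC(C)=O)c(OC(C)=O)c3oc2=O)cc1` differs from compound 3 by acetoxy in place of hydrogen on an aromatic carbon. Going by the values given here, the single measured step of this kind is unreadable, so no size within or beyond the scatter can be drawn from it. Compound 4 is accordingly expected to stay at the limit, with an estimated 40000 nM between 15000 nM and 150000 nM. The step from compound 3 to compound 4 that this estimate implies is expected to be a step that the limit leaves unreadable from compound 3 to compound 4.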

Compound 4, inhibition constant: > 30000 nM
Compound 4: a limit, no number; the forecaster's own chance of this, stated with the estimate: 85%; the middle value lies beyond the limit too.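

The step from compound 3 to compound 4 cannot be read because both values are limits, not numbers: the limit of > 30000 nM in this assay, at which 4 of the 4 values shown sit.

The compounds shown leave open whether acetoxy in place of hydrogen on an aromatic carbon shifts this read-out at all.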